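A few compounds are considered here, and "the series" means these few. Any claim that something is new, unique, unknown or untested is made for them only; others in the source may bear on it.

Measured compounds:
Compound 1 `O=C1CS/C(=N\c2csc(-c3cccc4ccccc34)c2)N1`: in a functional assay on MCF7 cells (Homo sapiens) for cytotoxicity, read by MTT assay, with a stated time of 72 h (on this read-out higher numbers stand for weaker inhibition and lower numbers for stronger inhibition), compound 1 gives > 50000 nM, a limit of the assay rather than a number.
Compound 2 `Cc1ccc(/C=C2\S/C(=N\c3nc(-c4ccc(Cl)cc4)cs3)NC2=O)cc1`: in this assay compound 2 gives 400 nM.
Compound 3 `COc1ccc(/C=C2\S/C(=N\c3nc(-c4ccc(Cl)cc4)cs3)NC2=O)cc1`: in this assay compound 3 gives 100 nM.

Compound 3 holds the lower of the two numbers shown. For the measured compounds named here, the only measured step, a 4.0-fold lower number from compound 2 to compound 3 (0.60 log units; beyond the scatter), exchanged the substituent para to the large group on the same six-membered ring.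

Compound 4 `O=C1N/C(=N/c2nc(-c3ccc(Cl)cc3)cs2)S/C1=C\c1ccc(F)cc1` differs from compound 3 by fluoro in place of methoxy on an aromatic carbon. That step alone bears on the change, being a swap at the same place; it was modest. A step of similar size, in the opposite direction, is expected here, a 2.5-fold higher number from compound 3 to compound 4 (0.40 log units; beyond the scatter). Compound 4 is therefore expected at about 250 nM, within 80 nM to 800 nM.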

Compound 4, half-maximal inhibitory concentration: > 50000 nM
Compound 4 was reported as a limit; the forecaster's own chance of this, stated with the estimate: 3%; middle value at least 200-fold (2.30 log units) away from the limit.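

In this assay fluoro in place of methoxy gives an at least 500-fold higher number from compound 3 to compound 4 (2.69 log units; beyond the scatter) and fluoro in place of methyl gives an at least 120-fold higher number from compound 2 to compound 4 (2.09 log units; beyond the scatter) against only a 4.0-fold lower number from compound 2 to compound 3 (0.60 log units; beyond the scatter) between methyl and methoxy. The group on this aromatic carbon, para to a large group, can therefore change the read-out far more than the methyl and methoxy pair suggested. Compound 4 stands at a limit of the assay and not at a number, so neither new step has a known size: the limit of > 50000 nM in this assay, at which 2 of the 4 values shown sit.

On these data alone, whether this loss is particular to fluoro stays open. Bromo, a hydroxyl or an amine on the same carbon would test that.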